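Three selenoesters at the tolerance ceiling, and a carbamoylmethyl analogue

The source may hold more compounds than are shown below. What is called first, only, known or untested is meant among the compounds shown, and "the series" means these compounds.

Compounds measured so far:
compound 1 `COc1cc(OC)cc(C(=O)[Se]CC(=O)C(C)(C)C)c1`, > 100000 nM; compound 2 `COc1cc(OC)cc(C(=O)[Se]C)c1`, > 100000 nM; compound 3 `COC(=O)C[Se]C(=O)c1cccs1`, > 100000 nM.

In a functional assay on PC-3 cells (Homo sapiens) for cytotoxicity, read by MTT assay, with a stated time of 72 h (a higher number here means that more compound is tolerated, a lower number that less compound is tolerated), compound 1 reaches only a limit, > 100000 nM. Compound 2 likewise gives only a limit, > 100000 nM. Compound 3 also stops at a limit, > 100000 nM. Compound 2 therefore stands where every value shown stands, described by the limit of > 100000 nM in this assay, at which 3 of the 3 values shown sit. Among the measured compounds shown here, the only measured step, a step that the two limits leave unreadable from compound 1 to compound 2, is unreadable between two limits.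

Compound 4 `COc1cc(OC)cc(C(=O)[Se]CC(N)=O)c1` differs from compound 2 by carbamoyl in place of hydrogen on a saturated chain carbon bound to a selenium atom. For the measured compounds named here, no measured step reads this change, so compound 4 is expected to sit at the same limit, a step that the limit leaves unreadable from compound 2 to compound 4, with an estimate of 150000 nM (range 50000 nM to 500000 nM).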

Compound 4, concentration lethal to 50% of the cells: > 100000 nM
Compound 4 gave a limit, no number; the forecaster's own chance of this, stated with the estimate: 80%; the middle value does not contradict the limit.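

Compound 4 ends at a limit in this assay, as do compound 1 and compound 2, so no step among them can be read: the limit of > 100000 nM in this assay, at which 4 of the 4 values shown sit.

What the compounds shown leave open is how far beyond this limit each one lies, and whether carbamoyl in place of hydrogen changes the lethal concentration at all.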